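This account rests on a few compounds, and the source may have more. Where it says the series, first, only, none or still open, it means among the compounds named here.

Measured so far:
compound 1 `CCc1nc2ccccc2n1CCCCOc1cccc(C)c1`: 19 uM
compound 2 `CCc1nc2ccc(C)cc2n1CCCCNc1ccccc1`: 21 uM

Both numbers come from an ADME assay on Vero cells (Chlorocebus sabaeus) for cytotoxicity, read by luminescence, with a stated time of 2 days; on this read-out lower numbers stand for higher toxicity in this test and higher numbers for lower toxicity in this test. In this assay compound 1 gives 19 uM, and compound 2 gives 21 uM. These two values sit within the usual scatter of each other, so compound 1 cannot be set apart from compound 2 on this basis: the two measurements are, in practice, the same result, and neither counts as more or less toxic than the other.

The next compound is compound 3 `CCc1nc2ccccc2n1CCCCOc1ccncc1`. It keeps the shared core of compound 1 and differs in one place only: pyridin-4-yl in place of 3-methylphenyl on an oxygen on a saturated carbon. Within the data shown here, no measured pair in this small set shows what such a swap does in this assay, so there is no measured step to lean on. Among the measured compounds shown here, the only guide is that the two measured compounds, which differ in more than one place, still gave the same result.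

The step expected is a 1.1-fold higher number from compound 1 to compound 3 (0.02 log units; within the scatter), that is, no shift beyond the scatter. Compound 3 is therefore estimated at 20 uM, with a range from 8 uM to 50 uM.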

Compound 3, half-maximal toxic concentration: > 50 uM
Compound 3: no number, only a limit; the forecaster's own chance of this, stated with the estimate: 10%; at least 2.5-fold (0.39 log units) between middle value and limit.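

In this assay compound 3 gives > 50 uM, which is a limit of the assay and not a number. Among these compounds, the group on the oxygen on a saturated carbon therefore turns out to matter: pyridin-4-yl in place of 3-methylphenyl gives an at least 2.6-fold higher number from compound 1 to compound 3 (0.42 log units; beyond the scatter), the first single-place change in this small set, and it points toward lower toxicity in this test. Since compound 3 has only a limit, this figure is a minimum and the full size of the step stays unknown, as the evidence shows: the limit of > 50 uM in this assay, at which 1 of the 3 values shown sits.

The swap removes a methyl group and brings in a ring nitrogen, which counts as a hydrogen-bond acceptor, all in one step, so the compounds shown cannot say which of these two differences matters; a plain phenyl or a pyridin-3-yl on the same oxygen would help to separate them. They also leave open how a more strongly charged group, such as an amine or a carboxylic acid on that ring, would read in this assay, and whether the same swap would have a similar effect on compound 2, which has a nitrogen link in place of the oxygen.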